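Chloro to trifluoromethyl in the series

The source may hold more compounds than are shown below. What is called first, only, known or untested is meant among the compounds shown, and "the series" means these compounds.

Measured in a physicochemical assay for lipophilicity, measured as octanol-water partition (on this read-out higher numbers stand for higher lipophilicity and lower numbers for lower lipophilicity), so far:
- compound 1 `N#Cc1c(-c2ccco2)[n+]([O-])c2ccc(Cl)cc2[n+]1[O-]` at 1.11
- compound 2 `Cc1ccc(-c2c(C#N)[n+]([O-])c3cc(Cl)ccc3[n+]2[O-])cc1` at 2.6

Of these two, compound 2 stands higher, beyond the scatter. Compound 3 `Cc1ccc(-c2c(C#N)[n+]([O-])c3cc(C(F)(F)F)ccc3[n+]2[O-])cc1` carries trifluoromethyl in place of chloro on an aromatic carbon. Going by the values given here, the one measured step (a number 1.49 log units higher from compound 1 to compound 2 (beyond the scatter)) is large, yet it is 4-methylphenyl in place of furan-2-yl on an aromatic carbon, a different change, so it gives little guidance on size. No step beyond the scatter is expected in this assay here. The expected step (a number 0.20 log units higher from compound 2 to compound 3 (within the scatter)) stays small. Compound 3 is estimated at 2.8 (2.4 to 3.2).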

Compound 3, partition coefficient: 2.95
Beside the measured number, compound 3's estimate is 0.15 log units below it, and the stated range covers the measured number.
By their numbers in this assay, from the lowest: compound 1; then compound 2; then compound 3.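

Trifluoromethyl in place of chloro on this aromatic carbon gives in this assay a number 0.35 log units higher from compound 2 to compound 3 (beyond the scatter) and so provides the first reading at this position, the earlier step having changed a different place. The step is modest, yet it lies beyond the scatter, so this read-out does respond to this change. Nothing on hand bears on the reason for the step.

On these data alone, what an amine, a carboxylic acid or a methoxy group would give on the same carbon stays open. Also open, as far as these compounds go, is whether the step holds with furan-2-yl in place of 4-methylphenyl.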